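This account rests on a few compounds, and the source may have more. Where it says the series, first, only, none or still open, it means among the compounds named here.

Three compounds share one core and differ only in the group on a saturated chain carbon bound to a carbonyl carbon. In a functional assay on CHO-K1 cells for antagonist activity at C-X-C chemokine receptor type 3 (Homo sapiens), read by FLIPR, with a stated time of 10 min, in the presence of a further agent that is not named here (on this read-out higher numbers stand for weaker inhibition and lower numbers for stronger inhibition), compound 1 `COC1CCN(CC(=O)N2CCN(c3sc(C(F)(F)F)nc3-c3nc4ccccc4[nH]3)C[C@H]2C)C1` gives 42 nM, compound 2 `C[C@@H]1CN(c2sc(C(F)(F)F)nc2-c2nc3ccccc3[nH]2)CCN1C(=O)CN1C(=O)OC[C@@H]1c1ccccc1` gives 360 nM, and compound 3 `C[C@@H]1CN(c2sc(C(F)(F)F)nc2-c2nc3ccccc3[nH]2)CCN1C(=O)Cn1cccn1` gives 13 nM, the lowest of the three numbers. Compound 4 `C[C@@H]1CN(c2sc(C(F)(F)F)nc2-c2nc3ccccc3[nH]2)CCN1C(=O)CN1CCC(F)(F)CC1` carries 4,4-difluoropiperidin-1-yl in place of 1H-pyrazol-1-yl on a saturated chain carbon bound to a carbonyl carbon. The step of a 3.2-fold lower number from compound 1 to compound 3 (0.51 log units; beyond the scatter) shows that the 3-methoxypyrrolidin-1-yl group in this place gave a higher number than the pyrazole, and a 28-fold lower number from compound 2 to compound 3 (1.44 log units; beyond the scatter) shows a far larger rise for the 2-oxo-4-phenyl-1,3-oxazolidin-3-yl group. Since compound 4 carries a non-aromatic ring bound through nitrogen, as compound 1 does, a modest rise is expected, a 3.1-fold higher number from compound 3 to compound 4 (0.49 log units; beyond the scatter). Compound 4 is therefore estimated at 40 nM, within 13 nM to 130 nM.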

Compound 4, half-maximal inhibitory concentration: 15 nM
Compound 4: middle estimate off by 2.7-fold (0.43 log units), on the high side, and the stated range covers the measured number.
By their numbers in this assay, from the lowest: compounds 3 and 4 (each within the scatter of the next); then compound 1; then compound 2.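

In this assay the 4,4-difluoropiperidin-1-yl group and the 1H-pyrazol-1-yl group cannot be told apart, with a 1.2-fold higher number from compound 3 to compound 4 (0.06 log units; within the scatter), so a non-aromatic ring at this place need not give a higher number. The other two steps, a 2.8-fold lower number from compound 1 to compound 4 (0.45 log units; beyond the scatter) and a 24-fold lower number from compound 2 to compound 4 (1.38 log units; beyond the scatter), show that non-aromatic rings here differ widely from one another, and the outcome follows the particular ring. No supporting measurement is available to explain these differences. The compounds shown leave open what a plain piperidin-1-yl group without fluorine, or an open-chain dimethylamino group, would give at this place.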